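From thiophen-3-yl to 1H-imidazol-4-yl: a toxicity forecast

A few compounds are considered here, and "the series" means these few. Any claim that something is new, unique, unknown or untested is made for them only; others in the source may bear on it.

In an ADME assay on BJ cells (Homo sapiens) for cytotoxicity, read by MTT assay, with a stated time of 72 h (on this read-out higher numbers stand for lower toxicity in this test and lower numbers for higher toxicity in this test), compound 1 `OC[C@H]1O[C@@H](n2cc(F)c3c(-c4ccccc4)ncnc32)[C@H](O)[C@@H]1O` gives > 50000 nM, which is a limit of the assay and not a number. For the measured compounds named here, compound 2 `OC[C@H]1O[C@@H](n2cc(F)c3c(-c4ccsc4)ncnc32)[C@H](O)[C@@H]1O` gives 620 nM, the only true number so far. Going by the values given here, the one measured step, an at least 80-fold lower number from compound 1 to compound 2 (1.90 log units; beyond the scatter), came from thiophen-3-yl in place of phenyl on an aromatic carbon. One end of that step rests on (the limit of > 50000 nM in this assay, at which 1 of the 2 values shown sits). Compound 3 `OC[C@H]1O[C@@H](n2cc(F)c3c(-c4c[nH]cn4)ncnc32)[C@H](O)[C@@H]1O` changes the same place again: 1H-imidazol-4-yl in place of thiophen-3-yl on an aromatic carbon, with 1H-imidazol-4-yl in place of thiophen-3-yl. Swapping this group alone moved the result strongly in an at least 80-fold lower number from compound 1 to compound 2 (1.90 log units; beyond the scatter), so a clear move back toward higher numbers in this assay is expected, though probably a smaller one. The expected change is an 8.1-fold higher number from compound 2 to compound 3 (0.91 log units; beyond the scatter). For compound 3 the estimated value is 5000 nM, within an expected range of 600 nM to 50000 nM.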

Compound 3, half-maximal cytotoxic concentration: > 50000 nM
Compound 3 gave a limit, no number (the forecaster's own chance of this, stated with the estimate: 30%); middle value at least 10-fold (1.00 log units) away from the limit.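

In this assay, a five-membered aromatic ring at this place does not by itself bring the low number seen for compound 2: 1H-imidazol-4-yl has the same count of heavy atoms as thiophen-3-yl, yet the swap gives an at least 80-fold higher number from compound 2 to compound 3 (1.90 log units; beyond the scatter). Compound 3 gives > 50000 nM, which is a limit of the assay and not a number. The step between compound 1 and compound 3 cannot be read, and among the three groups at this place only thiophen-3-yl gives a true number: the limit of > 50000 nM in this assay, at which 2 of the 3 values shown sit.

From the compounds shown here alone, it remains open whether the ring sulfur matters here, and furan-3-yl, with oxygen in its place, would be a direct test. Going by these compounds, how much higher the true values of compound 1 and compound 3 lie also remains unknown.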